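The source may report more compounds than this note shows. Statements on the series, on what has been measured and on what is new or still open speak of the compounds shown alone.

Among the compounds with values here, in a functional assay on Raji cells (Homo sapiens) for cytotoxicity, with a stated time of 72 h (on this read-out higher numbers stand for an effect only at larger amounts of compound and lower numbers for an effect already at smaller amounts), compound 1 `COc1ccc(/C=C/[C@@](C)(/C=C/c2ccc(O)c(C=O)c2)CCC=C(C)C)cc1` gives 13000 nM, the only true number so far. Compound 2 `CCOC(=O)/C(C)=C/c1cc(/C=C/[C@](C)(/C=C/c2ccc(OC)cc2)CCC=C(C)C)ccc1O` gives > 26000 nM, which is a limit. Compound 3 `COc1ccc(/C=C/[C@@](C)(/C=C/c2ccc(O)c(/C=C/C(=O)OCc3ccccc3)c2)CCC=C(C)C)cc1` gives > 26000 nM, which is likewise a limit, so it stands at the limit of > 26000 nM in this assay, at which 2 of the 3 values shown sit.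

Compound 4 `COc1ccc(/C=C/[C@@](C)(/C=C/c2ccc(O)c(/C=C/C(C)=O)c2)CCC=C(C)C)cc1` keeps the shared core and differs from compound 3 on a carbonyl carbon: methyl in place of benzyloxy on a carbonyl carbon. Within the data shown here, no measured step makes this exact change. The nearest evidence is an at least 2.0-fold higher number from compound 1 to compound 3 (0.30 log units; that floor lies within the scatter), together with an at least 2.0-fold higher number from compound 1 to compound 2 (0.30 log units; that floor lies within the scatter). Both are floors only, and a step that the two limits leave unreadable from compound 2 to compound 3 adds nothing on size.

A modest move toward lower numbers is expected, or none beyond the scatter, and a further limit remains quite possible. Among the measured compounds shown here, the only anchor for a number is compound 1 at 13000 nM. The step expected is an at least 1.3-fold lower number from compound 3 to compound 4 (0.11 log units; that floor lies within the scatter). For compound 4 the estimated value is 20000 nM, with an expected range from 8000 nM to 35000 nM.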

Compound 4, half-maximal effective concentration: > 26000 nM
Compound 4: a limit, no number; the forecaster's own chance of this, stated with the estimate: 45%; at least 1.3-fold (0.11 log units) between middle value and limit.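

With methyl in place of benzyloxy on a carbonyl carbon, the six-membered aromatic ring of the leaving group is gone, yet compound 4 in this assay still gives a limit and no number. Against the formyl group of compound 1, the 2-acetylethenyl group gives an at least 2.0-fold higher number from compound 1 to compound 4 (0.30 log units; that floor lies within the scatter), while the steps from compound 2 and compound 3 to compound 4 cannot be read. The ketone thus joins the two esters at the same limit: the limit of > 26000 nM in this assay, at which 3 of the 4 values shown sit.

Going by these compounds, how far compound 2, compound 3 and compound 4 lie from compound 1 remains open, and so does whether any of these groups truly differs from formyl beyond the scatter. Also open, on these data alone, is whether an amine or a carboxylic acid in place of methyl on a carbonyl carbon would give a true number.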